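Moving a Fluorine Across Four Related Compounds

The compounds below may be only part of what the source reports. "The series", "measured", "known", "first", "only" and "open" are said of these compounds alone.

Compound 1, compound 2 and compound 3 have been tested in a functional assay on SGC-7901 cells (Homo sapiens) for antiproliferative activity, read by MTT assay, with a stated time of 24 h; a lower number here means a stronger inhibitor, a higher number a weaker inhibitor. Compound 1 `O=c1[nH]cc(S(=O)(=O)Nc2ccccc2-c2cn(-c3cccc(F)c3)nn2)c(=O)[nH]1` gives only a limit of the assay, > 20000 nM. Compound 2 `O=c1[nH]cc(S(=O)(=O)Nc2ccccc2-c2cn(-c3ccc(F)cc3)nn2)c(=O)[nH]1` likewise reaches only the limit, > 20000 nM. Compound 3 `O=c1[nH]cc(S(=O)(=O)Nc2ccc(-c3cn(-c4cccc(F)c4)nn3)cc2)c(=O)[nH]1` also stops at the limit, > 20000 nM. The difference between the cores of compound 1 and compound 3 is not broken down here.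

From compound 1 to compound 2 the change is 4-fluorophenyl in place of 3-fluorophenyl on an aromatic nitrogen; the measured step is a step that the two limits leave unreadable from compound 1 to compound 2, unreadable because both values sit at the limit of > 20000 nM in this assay, at which 3 of the 3 values shown sit. Compound 4 `O=c1[nH]cc(S(=O)(=O)Nc2ccc(-c3cn(-c4ccc(F)cc4)nn3)cc2)c(=O)[nH]1` is not yet measured; it differs from compound 3 by 4-fluorophenyl in place of 3-fluorophenyl on an aromatic nitrogen, the same change made in the same place as from compound 1 to compound 2.

Given a step that the two limits leave unreadable from compound 1 to compound 2 and (the limit of > 20000 nM in this assay, at which 3 of the 3 values shown sit), compound 4 is expected to stay at the limit too, with an estimated step that the limit leaves unreadable from compound 3 to compound 4. The estimate for compound 4 in this assay is 35000 nM, with a range from 15000 nM to 100000 nM, most likely reported only as a limit.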

Compound 4, half-maximal inhibitory concentration: > 20000 nM
Compound 4: no number, only a limit; the forecaster's own chance of this, stated with the estimate: 90%; the middle value lies beyond the limit too.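

The step from compound 3 to compound 4 cannot be read, just like the one from compound 1 to compound 2, because all of these compounds give only a limit in this assay, not a number: (the limit of > 20000 nM in this assay, at which 4 of the 4 values shown sit). Going by these compounds, whether moving the fluorine, or the difference between the cores of compound 1 and compound 3, changes activity in this assay stays open.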